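The compounds below may be only part of what the source reports. "The series", "measured", "known", "first", "only" and "open" are said of these compounds alone.

Working notes on the series in an assay on HEK293 cells for positive allosteric modulation of metabotropic glutamate receptor 3 (Rattus norvegicus), read by thallium flux, with a stated time of 2.5 min; a lower number here means that less compound is needed, a higher number that more compound is needed for the effect.

Compound 1 `Cc1cc(C(=O)O)ccc1OCCCCOc1ccc(C(=O)CC(C)C)c(O)c1C` gives 1850 nM in this assay. Compound 2 `Cc1c(OCCCCOc2ccc(C(=O)O)cc2F)ccc(C(=O)CC(C)C)c1O` gives 1420 nM in this assay. For the measured compounds named here, the one step between them, a 1.3-fold lower number from compound 1 to compound 2 (0.11 log units; within the scatter), lies within the scatter; compound 2 therefore holds the lowest of the two numbers, but the two numbers cannot be told apart.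

Compound 3 `Cc1c(OCCCCOc2ccc(C(=O)O)cc2)ccc(C(=O)CC(C)C)c1O` is not yet measured. Its change from compound 2 is hydrogen in place of fluoro on an aromatic carbon. Going by the values given here, the only step that bears on it is the one on the same aromatic carbon, a 1.3-fold lower number from compound 1 to compound 2 (0.11 log units; within the scatter), which stayed within the scatter; no step yet exchanges fluoro for hydrogen. With that single within-scatter precedent, no step beyond the scatter is expected in this assay in either direction.

For compound 3 the expected value in this assay is 1600 nM, with a range of 800 nM to 3200 nM, an expected step of a 1.1-fold higher number from compound 2 to compound 3 (0.05 log units; within the scatter).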

Compound 3, half-maximal effective concentration: 2720 nM
Estimate against measurement, compound 3: 1.7-fold (0.23 log units) below, within the range that was stated.
By their numbers in this assay, from the lowest: compounds 2, 1 and 3 (each within the scatter of the next).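

In this assay, going from the 4-carboxy-2-fluorophenyl group to the 4-carboxyphenyl group gives a 1.9-fold higher number from compound 2 to compound 3 (0.28 log units; within the scatter), and hydrogen in place of methyl on the same aromatic carbon gives a 1.5-fold higher number from compound 1 to compound 3 (0.17 log units; within the scatter). With hydrogen now read alongside fluoro and methyl on this carbon, ortho to a large group and meta to a carboxy group, all three steps among compounds 1, 2 and 3 stay within the scatter, so the assay does not separate these three substituents here. No measurement in hand offers an explanation for the numbers at this position.

On these data alone, whether an amine, a methoxy group or a trifluoromethyl group on this carbon would give a step beyond the scatter stays open. So does the outcome of a longer chain in place of the one joining the two parts of these compounds.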